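The source may hold more compounds than are shown below. What is called first, only, known or untested is meant among the compounds shown, and "the series" means these compounds.

In an assay on isolated protein for inhibition of Apoptosis regulator Bcl-2 (Homo sapiens), read by fluorescence polarization, with stated times of 5 min and 10 min (a lower number here means a stronger inhibitor, a higher number a weaker inhibitor), compound 1 `CC(C)=CCCC1=CC[C@@H](C(=O)N(C)C)[C@H](c2ccccc2)C1` gives > 23000 nM, which is a limit of the assay rather than a number. Compound 2 `COC(=O)CCNC(=O)[C@@H]1CC=C(CCC=C(C)C)C[C@H]1c1ccccc1` likewise gives > 23000 nM, again a limit. Within the data shown here, compound 3 `COC(=O)CCNC(=O)[C@H]1CC=C(CCC=C(C)C)C[C@@H]1c1ccccc1` is the mirror image of compound 2; in this assay compound 3 gives 3100 nM, the only number in the set. The step of an at least 7.4-fold lower number from compound 2 to compound 3 (0.87 log units; beyond the scatter) rests on (the fact that compounds 2 and 3 differ only in the configuration as drawn), while the step that the two limits leave unreadable from compound 1 to compound 2 stays unreadable because of the limit of > 23000 nM in this assay, at which 2 of the 3 values shown sit. Compound 4 `CC(C)=CCCC1=CC[C@H](C(=O)Nc2ccc(C(=O)O)cc2)[C@@H](c2ccccc2)C1` differs from compound 3 by 4-carboxyphenyl in place of 2-(methoxycarbonyl)ethyl on an amide-type nitrogen. Among the measured compounds shown here, no measured step changes the group on this amide-type nitrogen in a readable way, so no direction can be drawn from the data. Compound 4 is therefore expected to give 1500 nM, within 300 nM to 8000 nM. The expected step of a 2.1-fold lower number from compound 3 to compound 4 (0.32 log units; beyond the scatter) is thus estimated to stay modest.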

Compound 4, inhibition constant: > 23000 nM
Compound 4 ended at the assay's limit (the forecaster's own chance of this, stated with the estimate: 15%); at least 15-fold (1.18 log units) between middle value and limit.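

Among these compounds, the only readable change on this amide-type nitrogen goes against 4-carboxyphenyl: in this assay there is an at least 7.4-fold higher number from compound 3 to compound 4 (0.87 log units; beyond the scatter), with 4-carboxyphenyl in place of 2-(methoxycarbonyl)ethyl. So this position does respond to its substituent within the compound 3 configuration as drawn, which the earlier compounds could not show. The full size of the step cannot be read, for this reason: the limit of > 23000 nM in this assay, at which 3 of the 4 values shown sit.

From the compounds shown here alone, how a plain phenyl or a 2-carboxyethyl group on this nitrogen would read remains open. So does whether the aromatic ring or the carboxylic acid carries the step.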